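Cyclohexylamino amide from compound 1: expected paw-edema inhibition

The source may report more compounds than this note shows. Statements on the series, on what has been measured and on what is new or still open speak of the compounds shown alone.

Compound 1 `COc1cc2c(cc1OC)C(CC(=O)O)CC2` is the reference point; in a functional assay on the whole organism (strain Wistar) for inhibition, with Rattus norvegicus as the target, read by paw edema, with stated times of 60 min and 1 h, at a dose of 100 mg/kg by the oral route (a higher number here means more inhibition at the dose given (going by the name of the read-out), a lower number less inhibition), compound 1 gives 18.8%, the lowest of the three numbers measured. Compound 2 `CCCCCNC(=O)CC1CCc2cc(OC)c(OC)cc21`, carrying pentylamino on the carbonyl carbon, gives 34.4%, and compound 3 `COc1cc2c(cc1OC)C(CC(=O)NC1CCCC1)CC2`, carrying cyclopentylamino there, gives 40.6%. Compound 4 `COc1cc2c(cc1OC)C(CC(=O)NC1CCCCC1)CC2` differs from compound 1 by cyclohexylamino in place of hydroxy on a carbonyl carbon. The two steps from compound 1 to an amide bear on this change: a number 15.6 percentage points higher from compound 1 to compound 2 (beyond the scatter) and a number 21.8 percentage points higher from compound 1 to compound 3 (beyond the scatter). Between the two amides, a number 6.2 percentage points higher from compound 2 to compound 3 (within the scatter), so the two amides cannot be ordered. An upward step of similar size is therefore expected for compound 4, a number 21.2 percentage points higher from compound 1 to compound 4 (beyond the scatter). Compound 4 is estimated at 40%, within a range from 28% to 52%.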

Compound 4, a percentage reported as inhibition, in the whole organism at one dose (the size of the read-out at that dose, not a potency): 50%
Estimate against measurement, compound 4: 10 percentage points below; the range from low to high includes it.
By their numbers in this assay, from the lowest: compound 1; then compounds 2, 3 and 4 (each within the scatter of the next, the first and the last beyond it).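

Cyclohexylamino in place of hydroxy on the carbonyl carbon gives a number 31.2 percentage points higher from compound 1 to compound 4 (beyond the scatter), so an amide carrying a six-membered non-aromatic ring of carbon only also stands clear of the acid. Cyclohexyl in place of pentyl gives a number 15.6 percentage points higher from compound 2 to compound 4 (beyond the scatter), the first separation of a ring from the open chain, while cyclohexyl in place of cyclopentyl gives a number 9.4 percentage points higher from compound 3 to compound 4 (within the scatter) and leaves the two rings unordered. No measurement here accounts for these steps.

Open, as far as these compounds go, is whether phenylamino or morpholino on the carbonyl carbon would match cyclohexylamino. Also open, from the compounds shown here alone, is how a longer chain such as octylamino would compare with pentylamino.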